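Adding One Carbon to the Amide Chain of Compound 3

This account rests on a few compounds, and the source may have more. Where it says the series, first, only, none or still open, it means among the compounds named here.

Three amides sharing one core have been tested in a functional assay on the whole organism (strain Wistar) for inhibition, with Rattus norvegicus as the target, read by paw edema, with stated times of 60 min and 4 h, at a dose of 100 mg/kg by the oral route; a lower number here means less inhibition, a higher number more inhibition at the dose given (going by the name of the read-out). Compound 1 `CNC(=O)CC1CCc2cc(OC)c(OC)cc21` gives 29.7% in this assay. Compound 2 `CCNC(=O)CC1CCc2cc(OC)c(OC)cc21` gives 26.6%, and compound 3 `CCCCCNC(=O)CC1CCc2cc(OC)c(OC)cc21` gives 40.6%, the highest of the three numbers. The step of a number 3.1 percentage points lower from compound 1 to compound 2 (within the scatter) comes from one change, (methyl in place of hydrogen on a saturated chain carbon bound to an amide-type nitrogen). By contrast the step of a number 10.9 percentage points higher from compound 1 to compound 3 (beyond the scatter) and the step of a number 14 percentage points higher from compound 2 to compound 3 (beyond the scatter) both lie beyond the scatter.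

Compound 4 `CCCCCCNC(=O)CC1CCc2cc(OC)c(OC)cc21` has not yet been measured in this assay. It differs from compound 3 by methyl in place of hydrogen on a saturated chain carbon, five bonds along the chain from an amide-type nitrogen. This is the same kind of change as that from compound 1 to compound 2, yet the place is not the same: there the added carbon sits on a saturated chain carbon bound to an amide-type nitrogen, here five bonds along the chain from it. The two starting points also differ, since compound 3 carries butyl in place of hydrogen on a saturated chain carbon bound to an amide-type nitrogen relative to compound 1.

Because the earlier step of a number 3.1 percentage points lower from compound 1 to compound 2 (within the scatter) stayed within the scatter, the step from compound 3 to compound 4 is expected to be small as well, about a number 1.4 percentage points higher from compound 3 to compound 4 (within the scatter). Compound 4 is therefore estimated at 42%, expected to fall between 30% and 54%.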

Compound 4, a percentage reported as inhibition, in the whole organism at one dose (the size of the read-out at that dose, not a potency): 42.1%
Compound 4: middle estimate off by 0.1 percentage points, on the low side; the measured number falls inside the stated range.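

In this assay, the new step, a number 1.5 percentage points higher from compound 3 to compound 4 (within the scatter), is small, and the same methyl-for-hydrogen change was also small on the other starting point: the same change on two cores in this assay, a number 3.1 percentage points lower (within the scatter) from compound 1 to compound 2 and a number 1.5 percentage points higher (within the scatter) from compound 3 to compound 4, 4.6 percentage points apart, within the scatter of two such steps The larger steps, a number 15.5 percentage points higher from compound 2 to compound 4 (beyond the scatter) and a number 12.4 percentage points higher from compound 1 to compound 4 (beyond the scatter), both separate the two shortest amides from compound 4, and the butyl-for-hydrogen change gave a similar rise on two different starting points, although at different places on the chain: the same change on two cores in this assay, a number 10.9 percentage points higher (beyond the scatter) from compound 1 to compound 3 and a number 15.5 percentage points higher (beyond the scatter) from compound 2 to compound 4, 4.6 percentage points apart, within the scatter of two such steps This shows agreement within these four compounds only: it rests on two pairs for each change, so it does not establish a rule that would carry to other cores, and it does not explain why the numbers differ.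

The compounds shown leave open whether a longer chain would hold the number at the level of compound 3 and compound 4, or whether it would rise or fall. They also leave open how a branched chain, or a chain carrying a phenyl ring or a carboxylic acid, would read in this assay.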